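The source may hold more compounds than are shown below. What is called first, only, known or untested is meant among the compounds shown, and "the series" means these compounds.

Working notes on the series. In a functional assay on HL-60 cells (Homo sapiens) for inhibition, read by MTT assay, with a stated time of 72 h (a lower number here means a stronger inhibitor, a higher number a weaker inhibitor), compound 1 (`Cc1ccc(C)c(N2CCN(C(=O)c3oc(C)nc3-c3ccccc3)CC2)c1`) gives 31.3 nM and compound 2 (`CCOc1cccc(N2CCN(C(=O)c3oc(C)nc3-c3ccccc3)CC2)c1`) gives 151 nM, so compound 2 holds the higher, weaker number of the two measured. Compound 3 (`CC(=O)Nc1cccc(N2CCN(C(=O)c3oc(C)nc3-c3ccccc3)CC2)c1`) keeps the shared core and differs from compound 2 by acetamido in place of ethoxy on an aromatic carbon, with acetamido in place of ethoxy on an aromatic carbon, meta to a large group. Within the data shown here, only one measured step bears on this change: a 4.8-fold higher number from compound 1 to compound 2 (0.68 log units; beyond the scatter), a modest step that exchanges one aryl group for another on the same amine nitrogen. Among the measured compounds shown here, no measured compound carries acetamido, so the direction is poorly supported. A modest step is expected in this assay, tentatively toward a higher number. The estimated step is a 1.7-fold higher number from compound 2 to compound 3 (0.22 log units; within the scatter). For compound 3 the estimate is 250 nM, with an expected range of 60 nM to 900 nM.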

Compound 3, half-maximal inhibitory concentration: 329 nM
Compound 3: middle estimate off by 1.3-fold (0.12 log units), on the low side, and the stated range covers the measured number.
By their numbers in this assay, from the lowest: compound 1; then compound 2; then compound 3.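

Acetamido in place of ethoxy, on an aromatic carbon meta to a large group, gives a 2.2-fold higher number from compound 2 to compound 3 (0.34 log units; beyond the scatter) in this assay, so a change at this one place alone moves the number beyond the scatter, and the entering group adds a hydrogen-bond donor that ethoxy lacks. Among these compounds, measured against 2,5-dimethylphenyl on the same amine nitrogen, 3-acetamidophenyl gives an 11-fold higher number from compound 1 to compound 3 (1.02 log units; beyond the scatter), a large step and the widest span so far. Nothing in hand gives a cause for the rise in the number.

From the compounds shown here alone, the amide hydrogen and the larger group enter together here, so their separate contributions stay open. Going by these compounds, a primary amine or a methoxy group at the same place could help separate them, and the effect of either remains unknown.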